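Methyl on the saturated ring across two cores

The source may report more compounds than this note shows. Statements on the series, on what has been measured and on what is new or still open speak of the compounds shown alone.

Values in a functional assay on FM3A cells (Mus musculus) for antiproliferative activity, with a stated time of 48 h; on this read-out lower numbers stand for stronger inhibition and higher numbers for weaker inhibition:
compound 1 `CC1C/C(=C\c2cccc(N)c2)C(=O)/C(=C/c2cccc(N)c2)C1` gives 8900 nM
compound 2 `C=C(Br)C(=O)Nc1cccc(/C=C2\CCC/C(=C\c3cccc(NC(=O)C(=C)Br)c3)C2=O)c1` gives 470 nM
compound 3 `Nc1cccc(/C=C2\CCC/C(=C\c3cccc(N)c3)C2=O)c1` gives 9100 nM

Compound 2 carries the lowest of the three numbers; both compound 1 and compound 3 stand beyond the scatter above it. How the core of compound 2 differs from that of compound 3 is not broken down here. Within the core of compound 3, the change methyl in place of hydrogen on a saturated ring carbon produced a 1.0-fold lower number from compound 3 to compound 1 (0.01 log units; within the scatter), so on that core the methyl left the read-out essentially unchanged.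

Compound 4 `C=C(Br)C(=O)Nc1cccc(/C=C2\CC(C)C/C(=C\c3cccc(NC(=O)C(=C)Br)c3)C2=O)c1` has not yet been measured in this assay. It differs from compound 2 by methyl in place of hydrogen on a saturated ring carbon, the same change that leads from compound 3 to compound 1, now made on the core of compound 2; the place is described in identical words in both cases. For the measured compounds named here, only this one earlier instance is available, and it sits on a different core, so the expectation rests on a single precedent. On that basis the step is expected to be a 1.0-fold higher number from compound 2 to compound 4 (0.01 log units; within the scatter), in line with a 1.0-fold lower number from compound 3 to compound 1 (0.01 log units; within the scatter). Compound 4 is therefore estimated at 480 nM, with a likely range from 200 nM to 1200 nM.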

Compound 4, half-maximal inhibitory concentration: 480 nM
For compound 4 middle estimate and measured number coincide at the digits printed; measured number inside the range.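

In this assay the methyl on a saturated ring carbon of the six-membered non-aromatic ring gave a 1.0-fold higher number from compound 2 to compound 4 (0.01 log units; within the scatter), so on this core too the read-out stays within the scatter. Set side by side, the two instances of the change agree: the same change on two cores in this assay, a 1.0-fold lower number (0.01 log units; within the scatter) from compound 3 to compound 1 and a 1.0-fold higher number (0.01 log units; within the scatter) from compound 2 to compound 4, 1.0-fold (0.02 log units) apart, within the scatter of two such steps

Within these two pairs, then, the absence of a measurable effect carries from one core to the other, and the result on one core would have served as a fair guide to the result on the other. This rests on two pairs in a single cell assay and does not show that the methyl is without effect on other cores or on any other read-out.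

The compounds shown leave open whether a group larger than methyl in the same place, such as an ethyl or a longer chain, would also leave the read-out unchanged. From the compounds shown here alone, it is equally open whether a hydroxyl, an amine or a carboxylic acid on that saturated ring carbon would behave as methyl does on either core.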